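Chloro for methoxy on compound 1: expected outcome

This account rests on a few compounds, and the source may have more. Where it says the series, first, only, none or still open, it means among the compounds named here.

Of the compounds shown here, three built on one shared core have been measured in an assay on isolated protein for inhibition of protein deacetylase HDAC6 (Homo sapiens), read by fluorescence, with a stated time of 90 min, tested at 1 uM; a lower number here means a weaker effect, a higher number a stronger effect of the compound at the concentration tested. Compound 1 `COc1ccc(C(=O)NO)cc1CNc1ccc2c(c1)cc(C)c(=O)n2C` gives 40%. Compound 2 `Cc1cc2cc(NS(=O)(=O)Cc3cccc(C(=O)NO)c3)ccc2n(C)c1=O` gives 63%, and compound 3 `COc1cc(C(=O)NO)ccc1CS(=O)(=O)Nc1ccc2c(c1)cc(C)c(=O)n2C` gives 15%. Compound 1 therefore stands second of the three: compound 2 lies higher by a margin beyond the scatter, and compound 3 lies lower by a margin that is also beyond the scatter. Among the compounds with values here, compounds 2 and 3 each differ from compound 1 in more than one place, so no single-point step between measured compounds is available, and nothing in the measured set isolates the effect of one substituent on the ring that carries the hydroxycarbamoyl group.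

Compound 4 `Cc1cc2cc(NCc3cc(C(=O)NO)ccc3Cl)ccc2n(C)c1=O` has not yet been measured. It differs from compound 1 in one place: chloro in place of methoxy on an aromatic carbon. The rest of compound 1, including the hydroxycarbamoyl group and the linker to the core, is unchanged.

Within the data shown here, with no measured step of this kind to draw on, the step from compound 1 to compound 4 is expected to be small, within the usual scatter in either direction, a number 2 percentage points higher from compound 1 to compound 4 (within the scatter). Compound 4 is expected to give about 42% in this assay, with a likely range from 22% to 62%.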

Compound 4, a percentage reported as inhibition, at one concentration (the size of the read-out at that concentration, not a potency): 28%
Compound 4: the middle estimate sits 14 percentage points above what was measured, within the range that was stated.
By their numbers in this assay, from the lowest: compound 3; then compound 4; then compound 1; then compound 2.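

In this assay, within the data shown here, chloro in place of methoxy on an aromatic carbon gives a number 12 percentage points lower from compound 1 to compound 4 (beyond the scatter) and provides the first reading of a change at a single place. The position ortho to a large group and para to a hydroxycarbamoyl group is therefore not indifferent to its substituent, and of the two groups compared there, methoxy gives the higher read-out. This is one step from one pair, so it establishes a direction for this exchange only and no trend across substituents, and nothing measured on these compounds bears on the reason for the change.

Still open, on these data alone, is how hydrogen, hydroxy, an amine or ethoxy at this position would compare with methoxy and chloro, which would show whether the read-out follows the size of the group or depends on the oxygen atom of methoxy. Also open, as far as these compounds go, is whether the same exchange would give a step of similar size and direction with a sulfonyl-containing linker to the shared core in place of the linker of compound 1.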